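Shifting the Trifluoromethyl on the Pyridinyl Amine Arm

The source may hold more compounds than are shown below. What is called first, only, known or untested is meant among the compounds shown, and "the series" means these compounds.

Measured compounds:
compound 1, `Cc1nc(C(=O)N2CCC3(CC3)C[C@H]2CNc2ccc(Cl)cn2)c(-c2ccccc2)s1`: < 5
compound 2, `Cc1ccc(-c2ncccn2)c(C(=O)N2CC3(CC3)C[C@H]2CNc2cc(C(F)(F)F)ccn2)n1`: 8.1

Of the compounds shown here, two have been measured in a functional assay on HEK293 cells for antagonist activity at Orexin receptor type 2 (Homo sapiens), read by FLIPR and calcium flux; on this read-out lower numbers stand for lower potency and higher numbers for higher potency (the scale is a negative logarithm). For compound 1 the result is a limit rather than a number, < 5; (the limit of < 5 in this assay, at which 1 of the 2 values shown sits). Among the compounds with values here, compound 2 gives 8.1 in this assay, the only number available here, so it stands alone and cannot be ranked against anything else. Within the data shown here, no step between measured compounds that differ in one place is available, so nothing measured shows how this series responds to a change of this kind.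

Compound 3, `Cc1ccc(-c2ncccn2)c(C(=O)N2CC3(CC3)C[C@H]2CNc2ccc(C(F)(F)F)cn2)n1`, has not been measured. It differs from compound 2 in this way: 5-(trifluoromethyl)pyridin-2-yl in place of 4-(trifluoromethyl)pyridin-2-yl on an amine nitrogen; the two have the same atoms, joined differently. Among the measured compounds shown here, with no measured step of this kind to lean on, the expected step is small, within the scatter, in either direction: a number 0.20 log units lower from compound 2 to compound 3 (within the scatter). Compound 3 is therefore expected to give about 7.9 in this assay, between 7 and 8.7.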

Compound 3, negative logarithm of the antagonist equilibrium constant: 7.5
Compound 3: the middle estimate sits 0.40 log units above what was measured; low and high end bracket the measured number.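

In this assay, within the data shown here, a step between compounds that differ in one place can now be read for the first time, and it is a number 0.60 log units lower from compound 2 to compound 3 (beyond the scatter). With the atoms unchanged and the counts of heavy atoms, donors and acceptors identical, this shows that where the trifluoromethyl sits on the pyridinyl ring carrying the amine nitrogen matters here, although compound 3 still gives 7.5, so the change does not abolish the activity. No measurement given here bears on what lies behind this step.

Going by these compounds, it remains open whether a step of this size would recur on a different core, since it rests on this single pair. Also open, on these data alone, is what a nitrile or a methoxy group would give in place of the trifluoromethyl at either site on the ring.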